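The source may report more compounds than this note shows. Statements on the series, on what has been measured and on what is new or still open speak of the compounds shown alone.

Three compounds share a core in which a sulfone bridge joins a trimethoxy-substituted styryl unit to a benzyl group. In a functional assay on K562 cells (Homo sapiens) for cytotoxicity, read by trypan blue exclusion, with a stated time of 96 h (a higher number here means a weaker inhibitor, a lower number a stronger inhibitor), compound 1 `COc1ccc(CS(=O)(=O)/C=C/c2c(OC)cc(O)cc2OC)cc1[N+](=O)[O-]` gives 5000 nM, compound 2 `COC(=O)CNc1cc(CS(=O)(=O)/C=C/c2c(OC)cc(OC)cc2OC)ccc1OC` gives 100 nM, and compound 3 `COC(=O)C(Nc1cc(CS(=O)(=O)/C=C/c2c(OC)cc(OC)cc2OC)ccc1OC)c1ccc(OC)cc1` gives 150 nM. Compound 2 has the lowest number of the three; compound 3 lies nearest to it, while compound 1 sits furthest away, a gap beyond the scatter. Among the measured compounds shown here, the one measured step, a 1.5-fold higher number from compound 2 to compound 3 (0.18 log units; within the scatter), shows that adding a 4-methoxyphenyl group on the chain carbon bound to the carbonyl carbon and the ring nitrogen changes little.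

Compound 4 `COc1cc(OC)c(/C=C/S(=O)(=O)Cc2ccc(OC)c(N[C@@H](C)C(=O)O)c2)c(OC)c1` differs from compound 2 by 1-carboxyethyl in place of (methoxycarbonyl)methyl on a nitrogen on an aromatic ring. For the measured compounds named here, no measured step touches this kind of exchange, since the step from compound 2 to compound 3 leaves the ester intact, so the direction is open. A modest rise in the number is expected, with the step from compound 2 to compound 4 estimated at a 3.0-fold higher number from compound 2 to compound 4 (0.48 log units; beyond the scatter). Compound 4 is therefore estimated to give 300 nM in this assay, with a range from 80 nM to 1500 nM.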

Compound 4, half-maximal inhibitory concentration: 15 nM
Estimate against measurement, compound 4: 20-fold (1.30 log units) above; measured number below the stated range.
By their numbers in this assay, from the lowest: compound 4; then compounds 2 and 3 (each within the scatter of the next); then compound 1.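

Among the compounds shown here, the nitrogen on the aromatic ring turns out to be a place where a change can matter: the exchange of (methoxycarbonyl)methyl for 1-carboxyethyl gives a 6.7-fold lower number from compound 2 to compound 4 (0.82 log units; beyond the scatter) in this assay and makes compound 4 the lowest number so far. Compound 3 could not show this, since its added 4-methoxyphenyl group left the ester in place and gave only a 1.5-fold higher number from compound 2 to compound 3 (0.18 log units; within the scatter). The new group brings a carboxylic acid, an extra methyl branch and a defined stereocentre all at once, and nothing available here explains the result.

Which of these three features accounts for the lower number remains open. A carboxymethyl group or a 1-(methoxycarbonyl)ethyl group on the same nitrogen would help separate them, and the mirror-image form of compound 4 would test the stereocentre.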